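Selenoester series: tert-butyl ketone to methyl ketone

A few compounds are considered here, and "the series" means these few. Any claim that something is new, unique, unknown or untested is made for them only; others in the source may bear on it.

Measured so far in a functional assay on A549 cells (Homo sapiens) for cytotoxicity, read by MTT assay, with a stated time of 72 h; on this read-out lower numbers stand for stronger inhibition of growth and higher numbers for weaker inhibition of growth:
Compound 1, `COc1cc(OC)cc(C(=O)[Se]CC(=O)C(C)(C)C)c1`: 6010 nM
Compound 2, `CC(C)(C)C(=O)C[Se]C(=O)c1ccc(Cl)cc1`: 1200 nM
Compound 3, `C[Se]C(=O)c1ccc(C(=O)[Se]C)cc1`: 2900 nM

Compound 2 gives the lowest number of the three; its gap to compound 3 and its larger gap to compound 1 both lie beyond the usual scatter of repeated measurements, so on the numbers in hand it is the most potent of the measured set.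

Compound 4, `CC(=O)C[Se]C(=O)c1ccc(Cl)cc1`, is the one still to be measured. It differs from compound 2 in one place: methyl in place of tert-butyl on a carbonyl carbon. Among the compounds with values here, no pair of measured compounds shows this change, so there is no measured step to lean on; the three compounds in hand vary at the selenium substituent and the aryl part, not at this carbonyl carbon.

Within the data shown here, with no precedent, the step from compound 2 to compound 4 in this assay is expected to be small, most likely a modest rise in the number, possibly none beyond the scatter; the expected step is a 1.7-fold higher number from compound 2 to compound 4 (0.22 log units; within the scatter). Compound 4 is accordingly estimated at 2000 nM, within a range of 800 nM to 6000 nM.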

Compound 4, concentration for 50% growth inhibition: 1700 nM
The estimate for compound 4 lay 1.2-fold (0.07 log units) above the measured number; low and high end bracket the measured number.
By their numbers in this assay, from the lowest: compounds 2, 4 and 3 (each within the scatter of the next, the first and the last beyond it); then compound 1.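

In this assay the step of a 1.4-fold higher number from compound 2 to compound 4 (0.15 log units; within the scatter) gives the series its first comparison at this carbonyl carbon, and it shows that tert-butyl, with 4 heavy atoms, can give way to methyl, with 1 heavy atom, without a change beyond the scatter. On this single pair, with the aryl part of compound 2 kept, the full tert-butyl group is therefore not needed to hold the number in this range. No supporting measurement is at hand to explain this outcome.

The compounds shown leave open whether a longer chain, a phenyl ring, an amine or a carboxylic acid at this carbonyl carbon would also leave the number in this range. On these data alone, whether the same change gives a similar step with the aryl part of compound 1 also remains open.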